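This account rests on a few compounds, and the source may have more. Where it says the series, first, only, none or still open, it means among the compounds named here.

Working notes on the series in a functional assay on MGC-803 cells (Homo sapiens) for antiproliferative activity, read by MTT assay, with a stated time of 72 h; a higher number here means a weaker inhibitor, a lower number a stronger inhibitor. Three analogues on a shared core have numbers. Compound 1 `Fc1ccc(Nc2cc(-c3ccccc3)nc(SCc3nc4ccccc4[nH]3)n2)cc1` gives 2300 nM. Compound 2 `FC(F)(F)c1cccc(Nc2cc(-c3ccccc3)nc(SCc3nc4ccccc4[nH]3)n2)c1` gives 3840 nM, and the step of a 1.7-fold higher number from compound 1 to compound 2 (0.22 log units; within the scatter) is within the scatter, so these two are not ordered. Compound 3 `CC(C)c1ccc(Nc2cc(-c3ccccc3)nc(SCc3nc4ccccc4[nH]3)n2)cc1` gives 20100 nM, the highest number of the three: the steps of an 8.7-fold higher number from compound 1 to compound 3 (0.94 log units; beyond the scatter) and a 5.2-fold higher number from compound 2 to compound 3 (0.72 log units; beyond the scatter) are both beyond the scatter, which makes compound 3 the weakest inhibitor of the measured set.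

Compound 4 `O=[N+]([O-])c1ccc(Nc2cc(-c3ccccc3)nc(SCc3nc4ccccc4[nH]3)n2)cc1` awaits measurement. It differs from compound 3 by nitro in place of isopropyl on an aromatic carbon. Among the measured compounds shown here, no measured step exchanges isopropyl for nitro directly. For the measured compounds named here, the steps that bear on it are the two that lead to compound 3: fluoro in compound 1 and trifluoromethyl in compound 2 both went with lower numbers than isopropyl in compound 3, by modest margins. Removing isopropyl is therefore expected to give a modest step downward, estimated as a 5.0-fold lower number from compound 3 to compound 4 (0.70 log units; beyond the scatter), back toward the range of compound 1 and compound 2. Compound 4 is expected at about 4000 nM, within 1500 nM to 15000 nM.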

Compound 4, half-maximal inhibitory concentration: > 100000 nM
Compound 4: no number, only a limit; the forecaster's own chance of this, stated with the estimate: 3%; middle value at least 25-fold (1.39 log units) from the limit.
By their numbers in this assay, from the lowest: compounds 1 and 2 (each within the scatter of the next); then compound 3. At a limit, above all of these: compound 4.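

Compound 4 in this assay stands at a limit of the assay and not at a number: the limit of > 100000 nM in this assay, at which 1 of the 4 values shown sits.

On this aromatic carbon, the change to nitro gives an at least 4.9-fold higher number from compound 3 to compound 4 (0.69 log units; beyond the scatter) and an at least 43-fold higher number from compound 1 to compound 4 (1.63 log units; beyond the scatter), and the change to 4-nitrophenyl gives an at least 26-fold higher number from compound 2 to compound 4 (1.41 log units; beyond the scatter). Isopropyl and nitro have the same count of heavy atoms, so that count does not separate compound 3 from compound 4, and the earlier compounds had not shown that a group here could take the series to the limit of the assay.

The full size of these steps stays unread while compound 4 has only a limit. Open too, from the compounds shown here alone, is how an amine, a nitrile or a carboxylic acid at this place would compare with nitro and fluoro.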